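The source may report more compounds than this note shows. Statements on the series, on what has been measured and on what is new or still open speak of the compounds shown alone.

Compound 2, with the structure `CCc1nnc(SC)n1N1C(=O)c2ccccc2C1=O`, is one of three measured members of this set. In a functional assay on PC-3M cells (Homo sapiens) for cytotoxicity, read by MTT assay, with a stated time of 48 h (on this read-out lower numbers stand for stronger inhibition and higher numbers for weaker inhibition), compound 2 gives > 200000 nM, which is a limit of the assay and not a number. Compound 1, `C#CCSc1nnc(CC)n1N1C(=O)c2ccccc2C1=O`, gives > 200000 nM in this assay, again a limit. Compound 3, `CCOC(=O)CSc1nnc(CC)n1N1C(=O)c2ccccc2C1=O`, likewise reaches only a limit of > 200000 nM in this assay. All three sit at the limit of > 200000 nM in this assay, at which 3 of the 3 values shown sit, so the steps between them — a step that the two limits leave unreadable from compound 1 to compound 2, a step that the two limits leave unreadable from compound 1 to compound 3 and a step that the two limits leave unreadable from compound 2 to compound 3 — cannot be read in size or direction.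

The unmeasured compound 4, `CCCc1nnc(SC)n1N1C(=O)c2ccccc2C1=O`, differs from compound 2 by methyl in place of hydrogen on a saturated chain carbon, two bonds along the chain from an aromatic carbon. For the measured compounds named here, none of the measured steps touches this chain; they all alter the group on the sulfur, and none of them yields a readable size. No measured change in this set has moved any compound off the limit. Compound 4 is therefore expected to give 300000 nM in this assay, with a plausible range from 100000 nM to 1000000 nM, most likely reported again as a limit. The step that the limit leaves unreadable from compound 2 to compound 4 is thus estimated to be no larger than the scatter.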

Compound 4, half-maximal inhibitory concentration: > 200000 nM
Compound 4: a limit, no number (the forecaster's own chance of this, stated with the estimate: 85%); the middle value lies beyond the limit too.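

Compound 4 gives > 200000 nM in this assay, again a limit and not a number. The change from compound 2 to compound 4 therefore cannot be read in size or direction: the limit of > 200000 nM in this assay, at which 4 of the 4 values shown sit.

The compounds shown leave open whether any change to the chain or the group on the sulfur would yield a number rather than a limit.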